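From a fluoro-methylphenyl arm to a methylphenyl arm

The source may report more compounds than this note shows. Statements on the series, on what has been measured and on what is new or still open speak of the compounds shown alone.

Compound 1 `C=CCn1c(=O)/c(=C\c2ccc(Cl)c(Cl)c2)[nH]c(=O)/c1=C\c1ccccc1`: in a functional assay on HeLa cells (Homo sapiens) for cytotoxicity, read by CCK-8 assay, with a stated time of 72 h (a lower number here means a stronger inhibitor, a higher number a weaker inhibitor), compound 1 is reported as "not active" (no number reported), with no number given.
Compound 2 `C=CCn1c(=O)/c(=C\c2cc(F)ccc2C)[nH]c(=O)/c1=C\c1ccccc1OC`: in this assay compound 2 gives 2900 nM.
Compound 3 `COc1ccccc1/C=c1\c(=O)[nH]/c(=C/c2ccccc2Cl)c(=O)n1C`: in this assay compound 3 gives 300 nM.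

Of the two compounds with a number, compound 2 stands at the higher one, the weaker inhibitor, while compound 3 sits at a markedly lower number, a gap beyond the scatter. Compound 4 `C=CCn1c(=O)/c(=C\c2ccc(C)cc2)[nH]c(=O)/c1=C\c1ccccc1OC` has not yet been measured. It differs from compound 2 in one place: 4-methylphenyl in place of 5-fluoro-2-methylphenyl on a double-bonded chain carbon bound to an aromatic carbon. Among the measured compounds shown here, no measured pair shows this same change, so its size is unknown. With compound 2 as the only close relative, the expected step is a 1.0-fold higher number from compound 2 to compound 4 (0.01 log units; within the scatter), small enough to lie within the scatter in either direction. Compound 4 is therefore expected to give 3000 nM, somewhere between 800 nM and 12000 nM.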

Compound 4, half-maximal inhibitory concentration: "not active" (no number reported)
For compound 4 the study gives words and no number; no gap can be computed for the estimate.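

Compound 4 is reported in words only, so no step from compound 2 to compound 4 can be read, and nothing shown accounts for this result. As far as these compounds go, the size of swapping 5-fluoro-2-methylphenyl for 4-methylphenyl remains open.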